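From 2-hydroxyphenyl to 4-hydroxyphenyl: compound 2 and compound 4

This account rests on a few compounds, and the source may have more. Where it says the series, first, only, none or still open, it means among the compounds named here.

- compound 1 `Oc1ccc(-c2cc(-c3ccccc3)cc(-c3ccco3)n2)cc1`: 10900 nM
- compound 2 `Oc1ccccc1-c1cc(-c2ccccc2)nc(-c2ccco2)c1`: 9700 nM
- compound 3 `Oc1cccc(-c2cc(-c3ccccc3)nc(-c3ccccn3)c2)c1`: 29800 nM

All three compounds were tested in a functional assay on HeLa cells (Homo sapiens) for cytotoxicity, read by ELISA, with a stated time of 2 days; a higher number here means a weaker inhibitor, a lower number a stronger inhibitor. Compound 2 sits level with compound 1 within the usual scatter, while compound 3 gives a higher number, a gap beyond that scatter.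

Compound 4 `Oc1ccc(-c2cc(-c3ccccc3)nc(-c3ccco3)c2)cc1` has not yet been measured. It keeps the atoms of compound 2 but joins them differently: 4-hydroxyphenyl stands in place of 2-hydroxyphenyl on an aromatic carbon, opposite the ring nitrogen (4-hydroxyphenyl in place of 2-hydroxyphenyl on an aromatic carbon).

For the measured compounds named here, no measured pair isolates this change, so the evidence is indirect. Compound 1 also carries a 4-hydroxyphenyl group, arranged differently on the shared core, and its 10900 nM gives no sign that this group sets it apart from compound 2. No shift beyond the scatter is therefore expected, and the estimated step is a 1.1-fold higher number from compound 2 to compound 4 (0.05 log units; within the scatter). Compound 4 is expected to give 11000 nM, with an estimated range from 4500 nM to 27000 nM.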

Compound 4, half-maximal inhibitory concentration: 4500 nM
Beside the measured number, compound 4's estimate is 2.4-fold (0.39 log units) above it, and the stated range covers the measured number.
By their numbers in this assay, from the lowest: compound 4; then compounds 2 and 1 (each within the scatter of the next); then compound 3.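

Taking the hydroxyl group from 2-hydroxyphenyl to 4-hydroxyphenyl, on the aromatic carbon opposite the ring nitrogen, gives a 2.2-fold lower number from compound 2 to compound 4 (0.33 log units; beyond the scatter) in this assay. For the compounds shown here, this is a modest step, but it is the first direct comparison of this change, and it shows that the number at this position can respond to where the hydroxyl group sits, even though the two compounds hold the same atoms. No measurement shown here accounts for the step.

Still open, on these data alone, is whether 3-hydroxyphenyl, carried with the furan-2-yl group kept in place, would sit level with compound 2 or compound 4. Also open, as far as these compounds go, is whether the hydroxyl group itself matters, which a methoxy group or an amine in its place on the phenyl ring could test.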